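A Benzyl Change at the Limit of the Assay

A few compounds are considered here, and "the series" means these few. Any claim that something is new, unique, unknown or untested is made for them only; others in the source may bear on it.

Measured so far in an ADME assay on Vero cells (Chlorocebus sabaeus) for cytotoxicity, read by MTT assay, with a stated time of 72 h; on this read-out lower numbers stand for higher toxicity in this test and higher numbers for lower toxicity in this test
Compound 1 (`O=c1nc(N2CCN(NCC3CCCC3)CC2)sc2c([N+](=O)[O-])cc(C(F)(F)F)cc12`) gives > 64 ug/mL
Compound 2 (`CON=C1CCC(N(C)N2CCN(c3nc(=O)c4cc(C(F)(F)F)cc([N+](=O)[O-])c4s3)CC2)CC1`) gives > 64 ug/mL
Compound 3 (`Cc1ccc(CNN2CCN(c3nc(=O)c4cc(C(F)(F)F)cc([N+](=O)[O-])c4s3)CC2)cc1`) gives > 64 ug/mL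

Compound 3 gives > 64 ug/mL as a limit of this assay and not as a number. The set as a whole shows the limit of > 64 ug/mL in this assay, at which 3 of the 3 values shown sit, and offers no number for comparison.

Compound 4 (`Cc1cccc(F)c1CNN1CCN(c2nc(=O)c3cc(C(F)(F)F)cc([N+](=O)[O-])c3s2)CC1`) differs from compound 3 by 2-fluoro-6-methylphenyl in place of 4-methylphenyl on a saturated chain carbon bound to an amine nitrogen and, in words, carries 2-fluoro-6-methylphenyl in place of 4-methylphenyl on a saturated chain carbon bound to an amine nitrogen.

The closest measured change is a step that the two limits leave unreadable from compound 1 to compound 3 and it falls on that same kind of chain carbon. The larger changes, a step that the two limits leave unreadable from compound 1 to compound 2 and a step that the two limits leave unreadable from compound 2 to compound 3, bear on it less directly. None of these steps has a readable size, and none points in a direction.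

The expected outcome is a number no higher from compound 3 to compound 4 (the limit leaves the size open) and no shift beyond the usual scatter is expected. For compound 4 the estimate is 64 ug/mL with an expected range from 32 ug/mL to 128 ug/mL and the assay will quite likely report only a limit.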

Compound 4, half-maximal cytotoxic concentration: > 64 ug/mL
Compound 4 ended at the assay's limit; the forecaster's own chance of this, stated with the estimate: 80%; the middle value lies on the limit itself.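

In this assay compound 4 gives > 64 ug/mL, which is a limit and not a number. Among these compounds, no step among compound 1, compound 2, compound 3 and compound 4 can be read: the limit of > 64 ug/mL in this assay, at which 4 of the 4 values shown sit. The compounds shown leave open whether any of these group changes alters this read-out at all.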